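Swapping tert-butyl for dimethylamino at the assay limit

The source may report more compounds than this note shows. Statements on the series, on what has been measured and on what is new or still open speak of the compounds shown alone.

In an ADME assay on Raji cells (Homo sapiens) for cytotoxicity, with a stated time of 72 h (a lower number here means that less compound is needed, a higher number that more compound is needed for the effect), compound 1 `Cc1cc(NC(=O)Nc2ccc(C(C)(C)C)cc2)c2ccccc2n1` gives > 25000 nM as a limit of the assay and not a number. Compound 2 `Cc1cc(NC(=O)Nc2ccc(F)c(F)c2)c2ccccc2n1` gives > 25000 nM which is again a limit. Compound 3 `Cc1cc(NC(=O)Nc2cccc(F)c2)c2ccccc2n1` gives > 25000 nM which is a limit too. The picture so far is therefore flat: the limit of > 25000 nM in this assay, at which 3 of the 3 values shown sit, and compound 1 has no true number to start from.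

Compound 4 `Cc1cc(NC(=O)Nc2ccc(N(C)C)cc2)c2ccccc2n1` is the same as compound 1 except for one change, dimethylamino in place of tert-butyl on an aromatic carbon and nothing else. Among the measured compounds shown here, the one measured step that the two limits leave unreadable from compound 2 to compound 3 concerns hydrogen in place of fluoro, a different change, and it offers no size to carry over. With no readable step to draw on, the expected step is a number no higher from compound 1 to compound 4 (the limit leaves the size open) and no direction is claimed. In this assay compound 4 is estimated at 25000 nM within a range of 10000 nM to 50000 nM and it will most likely be reported only as a limit.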

Compound 4, half-maximal effective concentration: > 25000 nM
Compound 4: no number, only a limit; the forecaster's own chance of this, stated with the estimate: 80%; the middle value sits exactly at the limit.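

Compound 1 and compound 4 each give only a limit of the assay and not a number, so no step can be read for the swap of tert-butyl to dimethylamino: the limit of > 25000 nM in this assay, at which 4 of the 4 values shown sit.

The compounds shown leave open whether any of these groups changes the concentration needed in this assay.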